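Swapping the aryl group on a piperazine: expected inactivity

This account rests on a few compounds, and the source may have more. Where it says the series, first, only, none or still open, it means among the compounds named here.

Compound 1 `Nc1scc(CN2CCN(c3ccc(F)cc3Cl)CC2)c1C(=O)c1ccc(Cl)cc1` gives 0% in an assay on CHO cells for displacement of a labelled ligand from adenosine receptor A1 (Homo sapiens), read by scintillation counting, with a stated time of 120 min, tested at 10 uM; on this read-out higher numbers stand for more inhibition at the one concentration tested (going by the name of the read-out) and lower numbers for less inhibition.
Compound 2 `Nc1scc(CN2CCN(c3ccc(Cl)cc3F)CC2)c1C(=O)c1ccc(Cl)cc1` gives 0% in this assay.
Compound 3 `Nc1scc(CN2CCN(c3ccccc3C(F)(F)F)CC2)c1C(=O)c1ccc(Cl)cc1` gives 0% in this assay.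

Compound 3 stands level with compound 1 and compound 2: none of the three shows any displacement in this assay. Compound 4 `Nc1scc(CN2CCN(c3ccc(OC(F)(F)F)cc3)CC2)c1C(=O)c1ccc(Cl)cc1` differs from compound 3 only in the aryl group on the ring nitrogen: 4-(trifluoromethoxy)phenyl in place of 2-(trifluoromethyl)phenyl on an amine nitrogen in a ring

The steps already measured are all swaps of this same aryl group, and each left the read-out unchanged: no change at the digits printed from compound 1 to compound 2 (within the scatter), no change at the digits printed from compound 1 to compound 3 (within the scatter) and no change at the digits printed from compound 2 to compound 3 (within the scatter). Nothing in these three compounds suggests that this part of the structure moves the read-out in this assay, so another aryl swap is expected to give no step beyond the scatter, and the expected step is no change at the digits printed from compound 3 to compound 4 (within the scatter). Compound 4 is therefore estimated at 0% in this assay. The expected lower end for compound 4 is -10%. The expected upper end for compound 4 is 15%.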

Compound 4, a percentage reported as inhibition, at one concentration (the size of the read-out at that concentration, not a potency): 0%
Beside the measured number, compound 4's estimate shows no gap at the digits printed, within the range that was stated.
By their numbers in this assay, from the lowest: compounds 1, 2, 3 and 4 (each within the scatter of the next).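

In this assay this assay, 4-(trifluoromethoxy)phenyl on the ring nitrogen gives no change at the digits printed from compound 3 to compound 4 (within the scatter), and the comparisons with the other two aryl groups agree, with no change at the digits printed from compound 2 to compound 4 (within the scatter) and no change at the digits printed from compound 1 to compound 4 (within the scatter). Until now every aryl group here carried only halogen or trifluoromethyl, whereas this one adds an oxygen atom and a hydrogen-bond acceptor, and the read-out still stays level across all four compounds. No supporting measurement is available to explain this flat result.

With no displacement from any of the four compounds, they cannot show whether this aryl group matters once some displacement is present. As far as these compounds go, it remains open whether an amine or a carboxylic acid on this phenyl ring, or a longer chain in place of it, would change the read-out.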